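From trifluoromethyl to cyano on the shared core

The compounds below may be only part of what the source reports. "The series", "measured", "known", "first", "only" and "open" are said of these compounds alone.

Measured in an ADME assay on H9c2 cells (Rattus norvegicus) for cytotoxicity; on this read-out higher numbers stand for weaker inhibition and lower numbers for stronger inhibition:
- Compound 1 `O=C(Nc1nc2ccc([N+](=O)[O-])cc2s1)C1CC1`: > 50000 nM
- Compound 2 `O=C(Nc1nc2ccc(C(F)(F)F)cc2s1)C1CC1`: > 50000 nM
- Compound 3 `O=C(Nc1nc2cc(F)c(C(F)(F)F)cc2s1)C1CC1`: > 50000 nM

Each of these entries is a limit of the assay and not a number. Compound 3 therefore has no exact position, and the series offers only (the limit of > 50000 nM in this assay, at which 3 of the 3 values shown sit).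

Compound 4 `N#Cc1cc2sc(NC(=O)C3CC3)nc2cc1F` carries cyano in place of trifluoromethyl on an aromatic carbon.

Among the compounds with values here, two measured steps bear on this change: a step that the two limits leave unreadable from compound 1 to compound 2, and a step that the two limits leave unreadable from compound 2 to compound 3. Neither has a readable size, so neither sets a direction. No step beyond the scatter is expected, and the estimated change is a step that the limit leaves unreadable from compound 3 to compound 4. A further report as a limit is the likeliest outcome in this assay. For compound 4 the estimated value is 60000 nM, with an expected range from 25000 nM to 120000 nM.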

Compound 4, half-maximal inhibitory concentration: > 50000 nM
Compound 4 ended at the assay's limit (the forecaster's own chance of this, stated with the estimate: 85%); the middle value does not contradict the limit.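

In this assay compound 4 gives > 50000 nM, a limit of the assay and not a number, so no new step can be read between compound 3 and compound 4. The compounds shown leave open whether cyano and trifluoromethyl differ at all on this read-out, and at what concentration any of these compounds would reach half-maximal inhibition.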